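From bromophenyl to chlorobenzyl on a sulfonyl sulfur

This account rests on a few compounds, and the source may have more. Where it says the series, first, only, none or still open, it means among the compounds named here.

Compound 1 `Cc1cc(C)cc(/C=C(\C(=O)c2ccc(Cl)cc2)S(=O)(=O)Cc2ccc(Cl)cc2)c1`: 1000 nM
Compound 2 `Cc1ccc(C)c(/C=C(\C(=O)c2ccc(Cl)cc2)S(=O)(=O)c2ccc(Br)cc2)c1`: 1000 nM
Compound 3 `COc1ccc(/C=C(\C(=O)c2ccc(Cl)cc2)S(=O)(=O)c2ccc(Br)cc2)cc1`: 10000 nM

These values come from a functional assay on DU-145 cells (Homo sapiens) for inhibition, read by trypan blue exclusion, with a stated time of 96 h; on this read-out lower numbers stand for stronger inhibition of growth and higher numbers for weaker inhibition of growth. Compound 2 stands level with compound 1, and together they hold the lowest number of the three. Compound 4 `Cc1ccc(C)c(/C=C(\C(=O)c2ccc(Cl)cc2)S(=O)(=O)Cc2ccc(Cl)cc2)c1` changes one group of compound 2: 4-chlorobenzyl in place of 4-bromophenyl on a sulfonyl sulfur. For the measured compounds named here, no measured step changes this place. Going by the values given here, the only step, a 10-fold higher number from compound 2 to compound 3 (1.00 log units; beyond the scatter), concerns a different group, so it sets no size here. Compound 1 already carries 4-chlorobenzyl on a sulfonyl sulfur and gives 1000 nM, although it differs from compound 4 elsewhere. The expected result is no change at the digits printed from compound 2 to compound 4 (within the scatter), with no shift beyond the scatter anticipated. For compound 4 the estimated value is 1000 nM, with an expected range of 300 nM to 4000 nM.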

Compound 4, concentration for 50% growth inhibition: 10000 nM
The estimate for compound 4 lay 10-fold (1.00 log units) below the measured number, and the stated range ends below it.
By their numbers in this assay, from the lowest: compounds 1 and 2 (each within the scatter of the next); then compounds 3 and 4 (each within the scatter of the next).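

The group on the sulfonyl sulfur does matter: 4-chlorobenzyl in place of 4-bromophenyl weakens growth inhibition (a 10-fold higher number from compound 2 to compound 4 (1.00 log units; beyond the scatter)). With 4-chlorobenzyl held fixed, moving the methyl groups also counts, as 2,5-dimethylphenyl in place of 3,5-dimethylphenyl shows a step of the same kind (a 10-fold higher number from compound 1 to compound 4 (1.00 log units; beyond the scatter)). No measurement here explains why either change has this effect. Still open, from the compounds shown here alone, is how 4-bromophenyl behaves alongside 3,5-dimethylphenyl, and whether a longer chain, an amine or a carboxylic acid on the sulfonyl sulfur would restore inhibition.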